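The source may hold more compounds than are shown below. What is called first, only, known or untested is meant among the compounds shown, and "the series" means these compounds.

Measured compounds:
compound 1, `Cc1ccc(C(=O)C(=C2NCCN2)c2c(Cl)c(F)c(C#N)c(F)c2C#N)cc1`, 41.9 ug/mL
compound 2, `Cc1ccc(C(=O)C(=C2NCCN2)c2c(F)c(F)c(C#N)c(F)c2C#N)cc1`, 0.9 ug/mL
compound 3, `N#Cc1c(F)c(Cl)c(C(C(=O)c2ccc(F)cc2)=C2NCCCCN2)c(C#N)c1F`, 2.1 ug/mL

The three measured compounds were tested in a functional assay on K562 cells (Homo sapiens) for antiproliferative activity, read by MTT assay; on this read-out lower numbers stand for stronger inhibition and higher numbers for weaker inhibition. Compound 1 gives 41.9 ug/mL, and compound 2, which differs from it by the change (fluoro in place of chloro on an aromatic carbon), gives 0.9 ug/mL; the step of a 47-fold lower number from compound 1 to compound 2 (1.67 log units; beyond the scatter) is large. Compound 3 gives 2.1 ug/mL in this assay; it stands nearest to compound 2 and far from compound 1. The difference between the core of compound 1 and the core of compound 3 is not broken down here.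

Compound 4, `N#Cc1c(F)c(F)c(C(C(=O)c2ccc(F)cc2)=C2NCCCCN2)c(C#N)c1F`, has not yet been measured in this assay. It differs from compound 3 by fluoro in place of chloro on an aromatic carbon, the same change that separates compound 1 from compound 2, and the surroundings of the place are the same in both pairs. That earlier step is the only example of this change among these compounds, so what it says about compound 4 rests on one pair. Compound 3 already sits far lower than compound 1, so the step from compound 3 to compound 4 is expected to be smaller than the earlier one, but still toward a lower number. The estimated step is a 7.0-fold lower number from compound 3 to compound 4 (0.85 log units; beyond the scatter), which rests on the step of a 47-fold lower number from compound 1 to compound 2 (1.67 log units; beyond the scatter). Compound 4 is therefore expected to give about 0.3 ug/mL in this assay, with the range from 0.05 ug/mL to 1.5 ug/mL.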

Compound 4, half-maximal inhibitory concentration: 0.3 ug/mL
The estimate for compound 4 equals the measured number at the digits printed; measured number inside the range.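

In this assay, fluoro in place of chloro on an aromatic carbon again goes toward a lower number, with a 7.0-fold lower number from compound 3 to compound 4 (0.85 log units; beyond the scatter). Set beside the earlier case, the direction of the change carries over from one core to the other, but its size does not: the same change on two cores in this assay, a 47-fold lower number (1.67 log units; beyond the scatter) from compound 1 to compound 2 and a 7.0-fold lower number (0.85 log units; beyond the scatter) from compound 3 to compound 4, 6.7-fold (0.82 log units) apart, beyond the scatter of two such steps. These two pairs show only that the direction held on these two cores; they do not show how the change would behave on any further core, and since the two cores differ in more than one place, they cannot tell which of those differences goes with the gap between the steps.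

The compounds shown leave open what other groups would do at the same place on the ring, such as bromo, methoxy or an amine, and whether any of them would give a number as low as fluoro does. They also leave open whether the step would keep its direction on a core carrying a different substituent on the aromatic ketone, such as a carboxylic acid or a longer chain, and how the fluoro and chloro pairs would compare on cells other than these.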